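Benzyl Substituent Variation on the Amide Nitrogen

The compounds below may be only part of what the source reports. "The series", "measured", "known", "first", "only" and "open" are said of these compounds alone.

Measured so far:
compound 1 `COC(=O)/C=C/c1cccc(N(C(=O)C2CCCCC2)c2ccc3ccccc3c2)c1` — 680 nM
compound 2 `COC(=O)/C=C/c1cccc(N(Cc2ccccc2Br)C(=O)C2CCCCC2)c1` — > 1000 nM
compound 3 `COC(=O)/C=C/c1cccc(N(Cc2cccc(Br)c2)C(=O)C2CCCCC2)c1` — > 1000 nM

In an assay on isolated protein with Bile acid receptor (Homo sapiens) as the target (a higher number here means that more compound is needed for the effect, a lower number that less compound is needed), compound 1 gives 680 nM. Compound 2 reaches only a limit of the assay, > 1000 nM. Compound 3 likewise reaches only a limit, > 1000 nM; note (the limit of > 1000 nM in this assay, at which 2 of the 3 values shown sit). From these follow an at least 1.4-fold higher number from compound 1 to compound 2 (0.16 log units; that floor lies within the scatter) and an at least 1.4-fold higher number from compound 1 to compound 3 (0.16 log units; that floor lies within the scatter), while a step that the two limits leave unreadable from compound 2 to compound 3. Compound 3 thus stands at the limit, with no number of its own. Compound 4 `COC(=O)/C=C/c1cccc(N(Cc2cccc(OC)c2)C(=O)C2CCCCC2)c1` differs from compound 3 by methoxy in place of bromo on an aromatic carbon. Within the data shown here, no measured step involves a methoxy group, so the only bearing is that compound 3 sits at the limit; no direction can be read from the steps. Compound 4 is expected near the same limit, a step that the limit leaves unreadable from compound 3 to compound 4, estimated at 1500 nM within 500 nM to 5000 nM.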

Compound 4, half-maximal effective concentration: > 1000 nM
Compound 4: a limit, no number; the forecaster's own chance of this, stated with the estimate: 60%; the middle value does not contradict the limit.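

In this assay compound 4 gives > 1000 nM, which is a limit and not a number. Among these compounds, the only readable step is an at least 1.4-fold higher number from compound 1 to compound 4 (0.16 log units; that floor lies within the scatter), and the steps from compound 2 and from compound 3 to compound 4 cannot be read. Replacing bromo with methoxy at this aromatic carbon therefore gives no number, and the benzyl compounds stay at the same limit: the limit of > 1000 nM in this assay, at which 3 of the 4 values shown sit.

Still open, going by these compounds, is whether any benzyl substituent gives a number in this assay, and how far apart compound 2, compound 3 and compound 4 lie. An amine or a carboxylic acid on this aromatic carbon would test the first point.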